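The source may hold more compounds than are shown below. What is called first, only, known or untested is meant among the compounds shown, and "the series" means these compounds.

Measured in a functional assay on MDA-MB-231 cells (Homo sapiens) for cytotoxicity, read by sulforhodamine B assay, with a stated time of 72 h; on this read-out lower numbers stand for stronger inhibition of growth and higher numbers for weaker inhibition of growth:
Compound 1 `COn1cc(C2CC(=O)N=C(N)N2)c2ccccc21` gives "not active" (no number reported)
Compound 2 `Cn1cc(C2CC(=O)N=C(N)N2)c2ccc(Br)cc21` gives 2860 nM
Compound 3 `Cn1cc(C2CCN=C(N)N2)c2ccccc21` gives 1710 nM

Compound 3, at 1710 nM, lies within the usual scatter of compound 2, at 2860 nM, so these two numbers set no order. Compound 1 has no number to set beside them.

Compound 4 `COn1cc(C2CCN=C(N)N2)c2ccccc21` is compound 3 with methoxy in place of methyl on an aromatic nitrogen. Among the measured compounds shown here, no measured pair shows this change alone, so the evidence is thin. For the measured compounds named here, the one hint comes from compound 1, which also carries methoxy on that nitrogen and reads "not active" (no number reported), although it also has a carbonyl that compound 4 lacks. A modest loss of growth inhibition in this assay is therefore expected, with a real chance of no change beyond the scatter. The estimated change is a 1.8-fold higher number from compound 3 to compound 4 (0.24 log units; within the scatter), towards a higher number. For compound 4 the expected value is 3000 nM ( estimated range 1000 nM to 10000 nM).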

Compound 4, concentration for 50% growth inhibition: "not active" (no number reported)
Compound 4: no number reported, so the estimate cannot be set against anything.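

In this assay compound 4 gives "not active" (no number reported) and so offers no number to set against compound 3, which means no step can be read from this pair. Nothing measured here bears on this result. The compounds shown leave open how large the effect of methoxy in place of methyl on an aromatic nitrogen is.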